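The source may hold more compounds than are shown below. What is called first, only, known or untested is meant among the compounds shown, and "the series" means these compounds.

Measured compounds:
compound 1, `COc1cc2ncnc(NNC(=S)NC(=O)c3ccc(Cl)cc3)c2cc1OC`, 7530 nM;
compound 2, `COc1cc2ncnc(NNC(=S)NC(=O)c3ccc(C)cc3)c2cc1OC`, 33300 nM;
compound 3, `O=C(NC(=S)NNc1ncnc2ccccc12)c1ccccc1Cl`, 6090 nM.

In a functional assay on CNE-2 cells (Homo sapiens) for cytotoxicity, read by MTT assay, with a stated time of 72 h (on this read-out higher numbers stand for weaker inhibition and lower numbers for stronger inhibition), compound 1 gives 7530 nM. The change (methyl in place of chloro on an aromatic carbon), at a place para to a large group, brings a 4.4-fold higher number from compound 1 to compound 2 (0.65 log units; beyond the scatter). Compound 3 carries a different core; the difference between the two cores is not broken down here. In this assay compound 3 gives 6090 nM, and against compound 1 the two values lie within the scatter of each other, so no order between them can be read.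

Compound 4, `Cc1ccccc1C(=O)NC(=S)NNc1ncnc2ccccc12`, has not been measured in this assay. It differs from compound 3 by methyl in place of chloro on an aromatic carbon, a place ortho to a large group rather than para to one, so it is the same kind of change as that from compound 1 to compound 2, not the same change. Compound 4 is expected to show a 3.0-fold higher number from compound 3 to compound 4 (0.47 log units; beyond the scatter), resting on the step of a 4.4-fold higher number from compound 1 to compound 2 (0.65 log units; beyond the scatter). The estimate for compound 4 in this assay is 18000 nM, between 7000 nM and 50000 nM.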

Compound 4, half-maximal inhibitory concentration: 5460 nM
Compound 4: middle estimate off by 3.3-fold (0.52 log units), on the high side; measured number outside the range, below it.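

In this assay, methyl in place of chloro brings a 1.1-fold lower number from compound 3 to compound 4 (0.05 log units; within the scatter), so compound 3 and compound 4 cannot be put in any order. Set beside the earlier step, the same change does not carry over from one core to the other with the same size: the same change on two cores in this assay, a 4.4-fold higher number (0.65 log units; beyond the scatter) from compound 1 to compound 2 and a 1.1-fold lower number (0.05 log units; within the scatter) from compound 3 to compound 4, 4.9-fold (0.69 log units) apart, beyond the scatter of two such steps. This shows that, within these two pairs, the effect of the change on one core does not predict its effect on the other, but it does not show why: the pairs differ in their cores and also in where the change sits, which in compound 4 is ortho to a large group, and the data cannot separate the two.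

Still open, from the compounds shown here alone, is whether the gap between the steps follows the core or the place of the change. Also open, going by these compounds, is how fluoro, trifluoromethyl or nitrile in place of the chloro would read on either core.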